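A few compounds are considered here, and "the series" means these few. Any claim that something is new, unique, unknown or untested is made for them only; others in the source may bear on it.

Measured compounds:
compound 1 `O=C1/C(=C/c2cccnc2)CN(S(=O)(=O)c2ccc([N+](=O)[O-])cc2)C/C1=C\c1ccccc1C(F)(F)F`: 15900 nM
compound 2 `O=C1/C(=C/c2cccnc2)CN(S(=O)(=O)c2ccc(C(F)(F)F)cc2)C/C1=C\c1ccccc1C(F)(F)F`: 1730 nM
compound 3 `O=C1/C(=C/c2ccncc2)CN(S(=O)(=O)c2ccc([N+](=O)[O-])cc2)C/C1=C\c1ccccc1C(F)(F)F`: > 20000 nM (a limit)

In a functional assay on SMMC-7721 cells (Homo sapiens) for cytotoxicity, read by MTT assay, with a stated time of 24 h (on this read-out higher numbers stand for weaker inhibition and lower numbers for stronger inhibition), compound 1 gives 15900 nM and compound 2 gives 1730 nM. For compound 3 the value of > 20000 nM is a limit of this assay, not a number. It sits at the limit of > 20000 nM in this assay, at which 1 of the 3 values shown sits. Compound 1 and compound 3 share the same atoms and differ in the core: pyridin-4-yl in place of pyridin-3-yl on a double-bonded chain carbon bound to a double-bonded ring carbon, giving an at least 1.2-fold higher number from compound 1 to compound 3 (0.09 log units; that floor lies within the scatter). Within the same core, the change trifluoromethyl in place of nitro on an aromatic carbon gives a 9.2-fold lower number from compound 1 to compound 2 (0.96 log units; beyond the scatter). Compound 4 `O=C1/C(=C/c2ccncc2)CN(S(=O)(=O)c2ccc(C(F)(F)F)cc2)C/C1=C\c1ccccc1C(F)(F)F` is not yet measured in this assay; it arises from compound 3 by the same change, (trifluoromethyl in place of nitro on an aromatic carbon). For compound 4 the expected step is an at least 4.4-fold lower number from compound 3 to compound 4 (0.64 log units; beyond the scatter), which rests on a 9.2-fold lower number from compound 1 to compound 2 (0.96 log units; beyond the scatter). Compound 3 has only a limit, and the starting point of that step is not fixed. Compound 4 is expected at 4500 nM, in a range from 1500 nM to 20000 nM.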

Compound 4, half-maximal inhibitory concentration: 3840 nM
For compound 4 the middle estimate is 1.2-fold (0.07 log units) above the measured one; measured number inside the range.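

In this assay, trifluoromethyl in place of nitro again lowers the number on the second core, with an at least 5.2-fold lower number from compound 3 to compound 4 (0.71 log units; beyond the scatter), so the direction carries over, but equal size on the two cores is not shown: the same change on two cores in this assay, a 9.2-fold lower number (0.96 log units; beyond the scatter) from compound 1 to compound 2 and an at least 5.2-fold lower number (0.71 log units; beyond the scatter) from compound 3 to compound 4; the limit leaves it open whether they differ

Pyridin-4-yl in place of pyridin-3-yl gives a 2.2-fold higher number from compound 2 to compound 4 (0.35 log units; beyond the scatter) on the trifluoromethyl core, and how this compares with the same change on the nitro core remains unsettled: the same change on two cores in this assay, an at least 1.2-fold higher number (0.09 log units; that floor lies within the scatter) from compound 1 to compound 3 and a 2.2-fold higher number (0.35 log units; beyond the scatter) from compound 2 to compound 4; the limit leaves it open whether they differ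

Compound 3 has > 20000 nM, which is a limit of the assay and not a number.

The compounds shown leave open whether an amine or a carboxylic acid in place of nitro on the aromatic ring would fit the same trend. From the compounds shown here alone, whether either change carries over to a core with another group in place of the 2-(trifluoromethyl)phenyl also remains open.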